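The source may report more compounds than this note shows. Statements on the series, on what has been measured and on what is new or still open speak of the compounds shown alone.

Measured so far:
compound 1 `CNC(=O)N1CCCc2ccc(NC(=O)c3cccc(-c4cnn(C)c4)c3)cc21`: 93.5%
compound 2 `CNC(=O)N1CCCc2ccc(NC(=O)c3cccc(-c4cn[nH]c4)c3)cc21`: 77.7%

In a functional assay on MV4-11 cells (Homo sapiens) for antiproliferative activity, with a stated time of 6 days, tested at 6.25 uM (on this read-out lower numbers stand for a weaker effect and higher numbers for a stronger effect at the one concentration tested), compound 1 gives 93.5%. Compound 2 gives 77.7%, the lower of the two numbers shown; its nearest neighbour is compound 1. For the measured compounds named here, the only measured step is a number 15.8 percentage points lower from compound 1 to compound 2 (beyond the scatter), hydrogen in place of methyl on an aromatic nitrogen.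

Compound 3 `CNC(=O)N1CCCc2ccc(NC(=O)c3cccc(-c4ccn(S(C)(=O)=O)n4)c3)cc21` is not yet measured. It differs from compound 2 by 1-(methylsulfonyl)-1H-pyrazol-3-yl in place of 1H-pyrazol-4-yl on an aromatic carbon. Going by the values given here, the one measured step bears on it only in part: removing the methyl from the aromatic nitrogen gave a modest loss in this assay, and compound 3 again carries a substituent, the methylsulfonyl, on the aromatic nitrogen of its five-membered ring, while the ring attaches through a different carbon, a change no measured pair covers. A step back toward the number of compound 1 is plausible, but the untested ring attachment leaves wide uncertainty. For compound 3 the expected step is a number 4.3 percentage points higher from compound 2 to compound 3 (within the scatter), a rise that may not exceed the scatter. Compound 3 is estimated at 82%, within 50% to 97%.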

Compound 3, a percentage reported as inhibition, at one concentration (the size of the read-out at that concentration, not a potency): 37%
Compound 3: the middle estimate sits 45 percentage points above what was measured, and the stated range ends above it.
By their numbers in this assay, from the lowest: compound 3; then compound 2; then compound 1.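

The position on the six-membered aromatic ring of carbon only, meta to a large group, tolerates less change than the first pair suggested: in this assay the change to 1-(methylsulfonyl)-1H-pyrazol-3-yl gives a number 40.7 percentage points lower from compound 2 to compound 3 (beyond the scatter) and, set against the 1-methyl-1H-pyrazol-4-yl group, a number 56.5 percentage points lower from compound 1 to compound 3 (beyond the scatter) in this series. Both steps are larger than a number 15.8 percentage points lower from compound 1 to compound 2 (beyond the scatter) on the same read-out, so a substituent on the ring nitrogen does not by itself keep the number high: compound 3 carries one and still has the lowest number of the three, beyond the scatter from both other compounds. No measurement at hand accounts for this drop.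

The change in compound 3 combines a new attachment carbon with a new nitrogen substituent, and the compounds shown do not separate the two; 1-methyl-1H-pyrazol-3-yl and 1-(methylsulfonyl)-1H-pyrazol-4-yl would each isolate one of them. Also open, going by these compounds, is how a longer chain, an amine or a carboxylic acid on the ring nitrogen would read at this position.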